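The source may report more compounds than this note shows. Statements on the series, on what has been measured and on what is new or still open speak of the compounds shown alone.

Compound 1 `Cc1cccc(Nc2ncnc3oc(C)c(CO)c23)c1` in a functional assay on A549 cells (Homo sapiens) for cytotoxicity, read by MTT assay, with a stated time of 72 h; a lower number here means a stronger inhibitor, a higher number a weaker inhibitor: 24000 nM
Compound 2 `Cc1oc2ncnc(Nc3ccc(OCc4cccc(F)c4)c(Cl)c3)c2c1C(=O)O` in this assay: 21400 nM
Compound 3 `Cc1oc2ncnc(Nc3cccc(Br)c3)c2c1C(=O)NCCO` in this assay: 17400 nM

Of the compounds shown here, three have been measured so far, and all three share the same core. Compound 1 gives the highest of the three numbers, but its gap to compound 2 and its gap to compound 3 both lie within the scatter of repeated measurements, so the three cannot be ranked against each other on these data.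

Compound 4 `Cc1cccc(Nc2ncnc3oc(C)c(C(=O)O)c23)c1` has not yet been measured. It differs from compound 1 in one place: carboxy in place of hydroxymethyl on an aromatic carbon. Compound 2 already carries a carboxy group at the same place on the core, alongside a different substituent on the aniline, and compound 3 carries an amide there. Both of them sit close to compound 1, so nothing in the measured set points to a large change when a carboxy replaces a hydroxymethyl on this core.

Compound 4 is therefore expected to land near compound 1, with a step of a 1.1-fold lower number from compound 1 to compound 4 (0.04 log units; within the scatter) that stays within the scatter. The estimate for compound 4 in this assay is 22000 nM, with a range from 8000 nM to 60000 nM.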

Compound 4, half-maximal inhibitory concentration: 100000 nM
Compound 4: middle estimate off by 4.5-fold (0.66 log units), on the low side; the whole stated range lies below it.
By their numbers in this assay, from the lowest: compounds 3, 2 and 1 (each within the scatter of the next); then compound 4.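

In this assay, putting carboxy in place of hydroxymethyl on the aromatic carbon next to the ring atom that bears a methyl group gives a 4.2-fold higher number from compound 1 to compound 4 (0.62 log units; beyond the scatter) with the rest of the molecule unchanged. Compounds 2 and 3 each differ from compound 1 in more than one place, so they could not show this position alone; this pair shows that the change at this position by itself is enough to weaken the cytotoxic effect beyond the scatter, though only modestly. Nothing measured here explains why the number rises.

The compounds shown leave open whether this step comes from the carboxy group itself or would also appear with another group at the same place, such as a methyl ester or an aminomethyl group. Among these compounds, they also leave open whether the same swap gives a step of similar size when the aniline part is the one carried by compound 2 or compound 3, as no matched pair with either of those aniline parts is available.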